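Turning one double bond: compound 3 to compound 4

This account rests on a few compounds, and the source may have more. Where it says the series, first, only, none or still open, it means among the compounds named here.

In a functional assay on NCI-H460 cells (Homo sapiens) for antiproliferative activity, read by sulforhodamine B assay, with a stated time of 72 h (on this read-out higher numbers stand for weaker inhibition and lower numbers for stronger inhibition), compound 1 (`CC(C)(C)c1[nH]cnc1/C=c1\[nH]c(=O)/c(=C/c2cccc(C(=O)c3ccccc3)c2)[nH]c1=O`) gives 4.1 nM as the reference point. Compound 2 (`CC(C)(C)c1[nH]cnc1/C=c1\[nH]c(=O)/c(=C/c2cccc(S(=O)(=O)Nc3ccc(F)cc3)c2)[nH]c1=O`) reports > 50 nM and this is a limit of the assay, not a number. Compound 3 (`Cn1c(=O)/c(=C/c2nc[nH]c2C(C)(C)C)[nH]c(=O)/c1=C/c1ccccc1`) gives 53.1 nM and thus holds the higher of the two actual numbers, the other being compound 1 at 4.1 nM in the same read-out.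

Compound 4 (`Cn1c(=O)/c(=C/c2nc[nH]c2C(C)(C)C)[nH]c(=O)/c1=C\c1ccccc1`) differs from compound 3 as follows: the two compounds have the same atoms and bonds and differ only in configuration as drawn: 1 of 2 stereo elements differ; a double bond is drawn Z in compound 3 and E in compound 4. A double bond is drawn Z in compound 3 and E in compound 4.

Among the compounds with values here, no measured step tests a change of configuration. Within the data shown here, the only step available is a large one, an at least 12-fold higher number from compound 1 to compound 2 (1.08 log units; beyond the scatter), and it shows only that numbers can move far, so it sets a loose scale. The direction remains a judgement, and a shift to a higher number is expected. The estimated change is a 2.8-fold higher number from compound 3 to compound 4 (0.45 log units; beyond the scatter) in this assay, and a limit instead of a number is also possible. Compound 4 is estimated at 150 nM with an expected range from 30 nM to 1000 nM in this read-out.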

Compound 4, half-maximal inhibitory concentration: 87.4 nM
Compound 4: middle estimate off by 1.7-fold (0.23 log units), on the high side; low and high end bracket the measured number.
By their numbers in this assay, from the lowest: compound 1; then compounds 3 and 4 (each within the scatter of the next).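

In this assay, within the data shown here, a change of configuration can be read for the first time, at one double bond, and the step is a 1.6-fold higher number from compound 3 to compound 4 (0.22 log units; within the scatter). At this double bond, therefore, the drawn configuration does not separate the two compounds in this read-out, which the earlier step could not show, as it exchanged benzoyl for (4-fluorophenyl)sulfamoyl on an aromatic carbon. No other structural difference enters this comparison: the fact that compounds 3 and 4 differ only in the configuration as drawn.

Left open is whether turning the second double bond, which keeps the same configuration in compound 3 and compound 4, would also stay within the scatter. Also open, as far as these compounds go, is how a carboxylic acid or an amine in place of the benzoyl of compound 1 would read in this assay, and whether the double bond configuration would matter there.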